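Para substituent on the aryl thiosemicarbazone: methoxy step

A few compounds are considered here, and "the series" means these few. Any claim that something is new, unique, unknown or untested is made for them only; others in the source may bear on it.

Compound 1 `CC1=CC[C@H](C(C)(C)NC(=S)N/N=C/c2ccccc2)CC1` gives 8400 nM in a functional assay on MCF7 cells (Homo sapiens) for inhibition, read by sulforhodamine B assay, with a stated time of 48 h; a lower number here means a stronger inhibitor of growth, a higher number a weaker inhibitor of growth.
Compound 2 `CC1=CC[C@H](C(C)(C)NC(=S)N/N=C/c2ccc(F)cc2)CC1` returns only an assay limit in this assay: > 100000 nM.
Compound 3 `CC1=CC[C@H](C(C)(C)NC(=S)N/N=C(\C)c2ccccc2)CC1` gives 20700 nM in this assay.

Among the two numbers measured, compound 3 stands highest, with compound 1 giving the lower number. Compound 4 `COc1ccc(/C(C)=N/NC(=S)NC(C)(C)[C@H]2CC=C(C)CC2)cc1` differs from compound 3 by methoxy in place of hydrogen on an aromatic carbon. Going by the values given here, the only measured step at that aromatic position is an at least 11-fold higher number from compound 1 to compound 2 (1.07 log units; beyond the scatter), which carried the value to the limit of > 100000 nM in this assay, at which 1 of the 3 values shown sits. Among the compounds with values here, a methoxy is a different group from fluoro, so the transfer is uncertain, but the one precedent points toward a higher number; a rise is therefore expected, a 2.2-fold higher number from compound 3 to compound 4 (0.34 log units; beyond the scatter), with a real chance of a limit. Compound 4 is estimated at 45000 nM, within 12000 nM to 150000 nM.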

Compound 4, concentration for 50% growth inhibition: 5000 nM
The estimate for compound 4 lay 9.0-fold (0.95 log units) above the measured number; the whole stated range lies above it.
By their numbers in this assay, from the lowest: compounds 4 and 1 (each within the scatter of the next); then compound 3. At a limit, above all of these: compound 2.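

Methoxy in place of hydrogen, para to a large group, gives a 4.1-fold lower number from compound 3 to compound 4 (0.62 log units; beyond the scatter) in this assay, so substitution at this position can lower the number. Going by these compounds alone, the one earlier step here, with fluoro, ran the other way from a different parent: an at least 11-fold higher number from compound 1 to compound 2 (1.07 log units; beyond the scatter). Compound 2 stands at a limit of the assay, not a number: the limit of > 100000 nM in this assay, at which 1 of the 4 values shown sits.

The opposite directions cannot yet be assigned to the group alone, since no single parent carries both fluoro and methoxy. Going by these compounds, how an amine or a hydroxyl at this position would read remains open.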